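Phenyl in Place of 4-Methylbenzyl on the Amide Nitrogen

The source may hold more compounds than are shown below. What is called first, only, known or untested is meant among the compounds shown, and "the series" means these compounds.

Going by the values given here, compound 3 `Cc1ccc(CNC(=O)/C=C/c2coc3cc(O)ccc3c2=O)cc1` is the one member of this small set with a numerical reading: in a functional assay on A549 cells (Homo sapiens) for inhibition, read by MTT assay, with a stated time of 48 h (a lower number here means a stronger inhibitor, a higher number a weaker inhibitor), compound 3 gives 17400 nM. Compound 1 `O=C(/C=C/c1coc2cc(O)ccc2c1=O)NCc1ccc(F)cc1` reaches only a limit of > 100000 nM in this assay. Compound 2 `Cc1ccccc1NC(=O)/C=C/c1coc2cc(O)ccc2c1=O` likewise stops at a limit of > 100000 nM in this assay. Among the compounds with values here, compound 3 therefore stands alone as the sole number, while the other two values sit at the limit of > 100000 nM in this assay, at which 2 of the 3 values shown sit.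

Compound 4 `O=C(/C=C/c1coc2cc(O)ccc2c1=O)Nc1ccccc1` has not yet been measured. Its difference from compound 3 is phenyl in place of 4-methylbenzyl on an amide-type nitrogen. Within the data shown here, two measured steps bear on this change. The step of an at least 5.7-fold lower number from compound 2 to compound 3 (0.75 log units; beyond the scatter) shows that moving from an aryl attached directly to the amide nitrogen to a benzyl group gave an at least modestly lower number; compound 4 runs the other way, back to an aryl sitting directly on that nitrogen. The step of an at least 5.7-fold lower number from compound 1 to compound 3 (0.75 log units; beyond the scatter) shows that the methyl present in compound 3 went along with a lower number, and compound 4 carries neither methyl nor fluoro. Both steps point to a higher number for compound 4, with a real chance of only a limit.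

Compound 4 is expected to give about 90000 nM in this assay, estimated to lie between 20000 nM and 300000 nM. The expected change is a 5.2-fold higher number from compound 3 to compound 4 (0.71 log units; beyond the scatter).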

Compound 4, half-maximal inhibitory concentration: 24400 nM
Estimate against measurement, compound 4: 3.7-fold (0.57 log units) above; measured number inside the range.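

The change from 4-methylbenzyl to phenyl on the amide-type nitrogen gives in this assay a 1.4-fold higher number from compound 3 to compound 4 (0.15 log units; within the scatter), so an aryl group sitting directly on that nitrogen does not by itself carry the reading to a limit. What set the 2-methylphenyl amide apart goes instead with its methyl: hydrogen in place of that methyl gives an at least 4.0-fold lower number from compound 2 to compound 4 (0.61 log units; beyond the scatter), a step read from a limit and not from a number. Phenyl in place of 4-fluorobenzyl likewise gives an at least 4.0-fold lower number from compound 1 to compound 4 (0.61 log units; beyond the scatter), also read from a limit, so the split between aryl and benzyl does not sort this set: compound 1 and compound 3 both carry a benzyl-type group, compound 2 and compound 4 both an aryl group, and each pair has one member at a limit and one with a number.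

From the compounds shown here alone, how far compound 1 and compound 2 truly lie from the other two stays open, as their values are limits and not numbers: the limit of > 100000 nM in this assay, at which 2 of the 4 values shown sit. Also open is how unsubstituted benzyl, 4-methylphenyl or a longer chain such as 2-phenylethyl on the amide-type nitrogen would read.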